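Swapping pyridin-2-yl for quinolin-3-yl on the shared core

This account rests on a few compounds, and the source may have more. Where it says the series, first, only, none or still open, it means among the compounds named here.

Measured so far in a physicochemical assay for solubility, in phosphate buffer, at pH 7.4 (on this read-out lower numbers stand for lower solubility and higher numbers for higher solubility), for two compounds:
- Compound 1 `N#CC1CCN(c2nccnc2OC2CN(c3ccc4ccccc4n3)C2)CC1` gives 66000 nM
- Compound 2 `c1ccc(-c2nccnc2OC2CN(c3ccc4ccccc4n3)C2)nc1` gives 349000 nM

Compound 2 stands highest of the two measured compounds, at 349000 nM in this assay as its reading. Compound 3 `c1ccc2ncc(-c3nccnc3OC3CN(c4ccc5ccccc5n4)C3)cc2c1` differs from it in one place, with quinolin-3-yl in place of pyridin-2-yl on an aromatic carbon and the rest of the structure unchanged. Within the data shown here, the only measured step at this place is a 5.3-fold higher number from compound 1 to compound 2 (0.72 log units; beyond the scatter) and it shows that the number can move beyond the scatter when the group there changes. Among the measured compounds shown here, no measured compound carries quinolin-3-yl, so the direction is a judgement and not a reading of the data. A step of similar size towards a lower number is expected. The estimated change is a 5.0-fold lower number from compound 2 to compound 3 (0.70 log units; beyond the scatter) for this swap. For compound 3 the estimate is 70000 nM with 12000 nM and 300000 nM as the expected ends of its range.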

Compound 3, solubility: < 1000 nM
Compound 3 was reported as a limit; the forecaster's own chance of this, stated with the estimate: 5%; middle value at least 70-fold (1.84 log units) from the limit.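

In this assay, the swap to quinolin-3-yl gives an at least 340-fold lower number from compound 2 to compound 3 (2.54 log units; beyond the scatter), and the same group set against 4-cyanopiperidin-1-yl gives an at least 66-fold lower number from compound 1 to compound 3 (1.81 log units; beyond the scatter). The earlier pair showed only a 5.3-fold higher number from compound 1 to compound 2 (0.72 log units; beyond the scatter), so this position on an aromatic carbon next to the ring nitrogen now proves able to carry a far larger change, even between two groups that each hold a six-membered aromatic ring with 1 hetero atom. The reading of compound 3 is a limit of the assay and not a number: the limit of < 1000 nM in this assay, at which 1 of the 3 values shown sits.

The compounds shown leave open how far the number truly falls for compound 3, and whether the added ring of carbon only in quinolin-3-yl is what matters. A phenyl group at this place, or a pyridin-2-yl carrying an amine or a carboxylic acid, would speak to how the number follows the group here.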